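The source may hold more compounds than are shown below. What is called first, only, known or untested is meant among the compounds shown, and "the series" means these compounds.

Measured so far:
compound 1, `CC[C@H](C)[C@H](N)CN(C(=O)[C@@H]1C[C@H]1c1ccc(F)c(F)c1)c1ccc(-c2ccccc2)cc1`, gives 720 nM in a functional assay for agonist activity at G protein-coupled receptor 88 (Homo sapiens), read by HTRF and cAMP accumulation; a lower number here means that less compound is needed, a higher number that more compound is needed for the effect.
compound 2, `CC(C)C[C@H](N)CN(C(=O)[C@@H]1C[C@H]1c1ccccc1)c1ccc(C2=CCCCCC2)cc1`, gives 2100 nM in this assay.

Compound 2 stands at the higher of the two numbers, and its gap to compound 1 lies beyond the usual scatter; the two differ in several places at once, so no single change can be held responsible for that gap.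

Compound 3, `CC(C)C[C@H](N)CN(C(=O)[C@@H]1C[C@H]1c1ccccc1)c1ccc(-c2ccc(F)cc2)cc1`, has not yet been measured. It differs from compound 2 in one place: 4-fluorophenyl in place of cyclohept-1-en-1-yl on an aromatic carbon. The rest of the molecule, including the amine-bearing side chain and the phenylcyclopropane amide, is unchanged.

For the measured compounds named here, no directly comparable pair has been measured, so the size of the step is uncertain. Compound 1, which also carries a biaryl group at this position, sits at the lower number, so a moderate move toward lower values is expected for compound 3, a 2.3-fold lower number from compound 2 to compound 3 (0.37 log units; beyond the scatter), with a wide range. The estimate for compound 3 is 900 nM, between 280 nM and 2900 nM.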

Compound 3, half-maximal effective concentration: 900 nM
Estimate against measurement, compound 3: no gap at the digits printed; the measured number falls inside the stated range.
By their numbers in this assay, from the lowest: compounds 1 and 3 (each within the scatter of the next); then compound 2.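

On the aromatic carbon para to a large group, the series now has its first single-place comparison: in this assay, 4-fluorophenyl in place of cyclohept-1-en-1-yl gives a 2.3-fold lower number from compound 2 to compound 3 (0.37 log units; beyond the scatter). The two groups have the same heavy-atom count, so this step compares a seven-membered non-aromatic carbon ring bearing a double bond with a fluorinated six-membered aromatic ring, and the size of the step is modest. No measurement at hand explains the step.

The change alters the ring and introduces the fluorine in a single step, leaving the contribution of each unresolved. Also open, from the compounds shown here alone, is how this assay would read with an unsubstituted phenyl, a 4-chlorophenyl or a 4-methoxyphenyl at this place on the otherwise unchanged molecule of compound 3.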